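Swapping One Saturated Ring for Another on a Shared Scaffold

The source may report more compounds than this note shows. Statements on the series, on what has been measured and on what is new or still open speak of the compounds shown alone.

Measured compounds:
Compound 1, `COc1cc2c(Oc3ccc(NC(=O)c4nn(-c5ccccc5C(F)(F)F)c(=O)cc4C)cc3F)ccnc2cc1OCCCN1CCC(C)CC1`: 1120 nM
Compound 2, `COc1cc2c(Oc3ccc(NC(=O)c4nn(-c5ccccc5C(F)(F)F)c(=O)cc4C)cc3F)ccnc2cc1OCCCN1CCN(C)CC1`: 1170 nM
Compound 3, `COc1cc2c(Oc3ccc(NC(=O)c4nn(-c5ccccc5OC(F)(F)F)c(=O)cc4C)cc3F)ccnc2cc1OCCCN1CCC(C)CC1`: 800 nM

All three were tested in a functional assay on U-87MG ATCC cells (Homo sapiens) for inhibition, read by MTT assay, with a stated time of 72 h; a lower number here means a stronger inhibitor, a higher number a weaker inhibitor. Compound 1 and compound 2 share one core and differ only in 4-methylpiperazin-1-yl in place of 4-methylpiperidin-1-yl on a saturated chain carbon, three bonds along the chain from an oxygen on an aromatic ring; that change gave a 1.0-fold higher number from compound 1 to compound 2 (0.02 log units; within the scatter). Compound 3 carries a different core, and the difference between the two cores is trifluoromethoxy in place of trifluoromethyl on an aromatic carbon, which gave a 1.4-fold lower number from compound 1 to compound 3 (0.15 log units; within the scatter).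

Compound 4, `COc1cc2c(Oc3ccc(NC(=O)c4nn(-c5ccccc5OC(F)(F)F)c(=O)cc4C)cc3F)ccnc2cc1OCCCN1CCN(C)CC1`, is the untested member of the set. It differs from compound 3 in 4-methylpiperazin-1-yl in place of 4-methylpiperidin-1-yl on a saturated chain carbon, three bonds along the chain from an oxygen on an aromatic ring, and the place of the change is the same, word for word, as in the pair already measured, so this is the same change seen once more on the other core.

Since the earlier instance of this change gave a 1.0-fold higher number from compound 1 to compound 2 (0.02 log units; within the scatter), the step from compound 3 to compound 4 is expected to be a 1.0-fold higher number from compound 3 to compound 4 (0.02 log units; within the scatter) in this assay. On that basis compound 4 is estimated at 830 nM, with a plausible range from 500 nM to 1400 nM.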

Compound 4, half-maximal inhibitory concentration: 1440 nM
For compound 4 the middle estimate is 1.7-fold (0.24 log units) below the measured one; the whole stated range lies below it.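

In this assay, 4-methylpiperazin-1-yl in place of 4-methylpiperidin-1-yl gave a 1.8-fold higher number from compound 3 to compound 4 (0.26 log units; within the scatter), and this step agrees with the same change on the other core: the same change on two cores in this assay, a 1.0-fold higher number (0.02 log units; within the scatter) from compound 1 to compound 2 and a 1.8-fold higher number (0.26 log units; within the scatter) from compound 3 to compound 4, 1.7-fold (0.24 log units) apart, within the scatter of two such steps. Trifluoromethoxy in place of trifluoromethyl, read on the two compounds that carry 4-methylpiperazin-1-yl, gave a 1.2-fold higher number from compound 2 to compound 4 (0.09 log units; within the scatter), and this step likewise agrees with its earlier instance: the same change on two cores in this assay, a 1.4-fold lower number (0.15 log units; within the scatter) from compound 1 to compound 3 and a 1.2-fold higher number (0.09 log units; within the scatter) from compound 2 to compound 4, 1.7-fold (0.24 log units) apart, within the scatter of two such steps. The two cores therefore cannot be told apart for either change, but every step here is within the scatter, so this does not show that a change carries over exactly, or that either change has a real effect on the number at all.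

As far as these compounds go, it remains open whether a different group at the end of the chain, such as morpholin-4-yl or dimethylamino, or a different chain length, would give a step large enough to compare between cores. A different group on the aromatic carbon, such as chloro or methoxy, poses the same open question.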